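A few compounds are considered here, and "the series" means these few. Any claim that something is new, unique, unknown or untested is made for them only; others in the source may bear on it.

Compound 1 `CC(C)[C@H](NC(=O)COc1cccc2ccccc12)C(=O)N[C@@H](CC(=O)O)C(=O)COc1ccccc1`: 11200 nM
Compound 2 `CC(C)[C@H](NC(=O)COc1cccc2ccccc12)C(=O)N[C@@H](CC(=O)O)C(=O)COc1ccc2ccccc2c1`: 15900 nM
Compound 3 `CC(C)[C@H](NC(=O)COc1cccc2ccccc12)C(=O)N[C@@H](CC(=O)O)C(=O)COc1ccc(C(F)(F)F)cc1`: 12300 nM

In a functional assay with Homo sapiens as the target (a higher number here means a weaker inhibitor, a lower number a stronger inhibitor), compound 1 shows the lowest of the three numbers, yet both gaps to its neighbours, a 1.1-fold higher number from compound 1 to compound 3 (0.04 log units; within the scatter) and a 1.4-fold higher number from compound 1 to compound 2 (0.15 log units; within the scatter), lie within the scatter, so none of the three can be called stronger or weaker. Compound 4 `CC(C)[C@H](NC(=O)COc1cccc2ccccc12)C(=O)N[C@@H](CC(=O)O)C(=O)COc1ccccc1F` differs from compound 1 by fluoro in place of hydrogen on an aromatic carbon. Going by the values given here, no measured step alters that same position; the closest comparison is the step from compound 1 to compound 3, a 1.1-fold higher number from compound 1 to compound 3 (0.04 log units; within the scatter), where a small group entering the same phenyl left the number within the scatter. A step of similar size, with no clear direction, is therefore expected for compound 4, namely a 1.0-fold lower number from compound 1 to compound 4 (0.01 log units; within the scatter). Compound 4 is accordingly estimated at 11000 nM, in the range 5000 nM to 25000 nM.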

Compound 4, half-maximal inhibitory concentration: 15700 nM
Beside the measured number, compound 4's estimate is 1.4-fold (0.15 log units) below it; the measured number falls inside the stated range.
By their numbers in this assay, from the lowest: compounds 1, 3, 4 and 2 (each within the scatter of the next).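

In this assay, going by these compounds alone, fluoro on an aromatic carbon ortho to a large group gives a small change (a 1.4-fold higher number from compound 1 to compound 4 (0.15 log units; within the scatter)), so this position, untouched in the earlier compounds, shows no readable effect from this change. Exchanging the whole group on the oxygen also leaves the numbers close (a 1.3-fold higher number from compound 3 to compound 4 (0.11 log units; within the scatter); a 1.0-fold lower number from compound 2 to compound 4 (0.01 log units; within the scatter)), so 2-fluorophenyl cannot be separated from 4-(trifluoromethyl)phenyl or naphthalen-2-yl. No supporting evidence is available to explain these results.

On these data alone, whether an amine or a hydroxyl group at this position would move the number beyond the scatter remains open.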